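Swapping a halogen for a methyl on the aryl ring

A few compounds are considered here, and "the series" means these few. Any claim that something is new, unique, unknown or untested is made for them only; others in the source may bear on it.

Measured compounds:
- compound 1, `CC(C)=CC/C=C(/C)C/C=N/NC(=O)Nc1nnc(-c2ccc(Cl)cc2)o1`: 300 mg/kg
- compound 2, `CC(C)=CC/C=C(/C)C/C=N/NC(=O)Nc1nnc(-c2ccc(F)cc2)o1`: 300 mg/kg

In a functional assay on the whole organism (strain Swiss albino) with Mus musculus as the target, with a stated time of 4 h (on this read-out higher numbers stand for an effect only at larger amounts of compound and lower numbers for an effect already at smaller amounts), compound 1 gives 300 mg/kg. Compound 2, in which fluoro replaces chloro on an aromatic carbon, gives 300 mg/kg in this assay, so the step of no change at the digits printed from compound 1 to compound 2 (within the scatter) lies within the scatter and compound 2 stands level with compound 1 on the numbers shown.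

Compound 3, `CC(C)=CC/C=C(/C)C/C=N/NC(=O)Nc1nnc(-c2ccc(C)cc2)o1`, is not yet measured. It differs from compound 2 in one place: methyl in place of fluoro on an aromatic carbon. Going by the values given here, the only measured step that bears on this change is the exchange of one small substituent for another at the same aromatic carbon, no change at the digits printed from compound 1 to compound 2 (within the scatter), which left the read-out unchanged. A change of similar kind is therefore expected to stay within the scatter, no change at the digits printed from compound 2 to compound 3 (within the scatter). Compound 3 is expected to give about 300 mg/kg in this assay, with a range from 150 mg/kg to 600 mg/kg.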

Compound 3, minimum effective dose: 300 mg/kg
For compound 3 middle estimate and measured number coincide at the digits printed; measured number inside the range.
By their numbers in this assay, from the lowest: compounds 1, 2 and 3 (each within the scatter of the next).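

The earlier pair compared only two halogens, whereas compound 3 places a methyl on the aromatic carbon para to a large group. In this assay, methyl in place of fluoro gives no change at the digits printed from compound 2 to compound 3 (within the scatter), and methyl in place of chloro gives no change at the digits printed from compound 1 to compound 3 (within the scatter), so at this position the read-out also stays level when a carbon group takes the place of either halogen. Nothing measured here explains why these three groups read alike.

As far as these compounds go, whether this position responds to groups of a different kind, such as an amine, a carboxylic acid or a longer chain, remains open. A plain hydrogen or a methoxy group here is also untested in the compounds shown, so the limits of this flat result are unknown.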